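Hydroxy to Acetoxy on Two Related Cores

A few compounds are considered here, and "the series" means these few. Any claim that something is new, unique, unknown or untested is made for them only; others in the source may bear on it.

Compound 1, `C=C1CC[C@@H]2[C@](C)(CO[Si](c3ccccc3)(c3ccccc3)C(C)(C)C)[C@H](OC(C)=O)CC[C@@]2(C)[C@@H]1C/C=C1/C(=O)OC[C@H]1O`, in a functional assay on P388 cells (Mus musculus) for cytotoxicity, read by sulforhodamine B assay (a lower number here means that less compound is needed, a higher number that more compound is needed for the effect), gives 0.5 uM.
Compound 2, `C=C1CC[C@@H]2[C@](C)(CO[Si](C)(C)C(C)(C)C)[C@H](O)CC[C@@]2(C)[C@@H]1C/C=C1/C(=O)OC[C@H]1O`, in this assay gives 8.39 uM.
Compound 3, `C=C1CC[C@@H]2[C@](C)(CO[Si](c3ccccc3)(c3ccccc3)C(C)(C)C)[C@H](O)CC[C@@]2(C)[C@@H]1C/C=C1/C(=O)OC[C@H]1O`, in this assay gives 0.68 uM.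

Compound 1 differs from compound 3 only by acetyl in place of hydrogen on an oxygen on a saturated carbon, and this change gave a 1.4-fold lower number from compound 3 to compound 1 (0.13 log units; within the scatter). Compound 2 and compound 3 share much of their structure, but the difference between the two cores is not broken down here; compound 2 stands well apart from both others in this assay. The unmeasured compound 4, `C=C1CC[C@@H]2[C@](C)(CO[Si](C)(C)C(C)(C)C)[C@H](OC(C)=O)CC[C@@]2(C)[C@@H]1C/C=C1/C(=O)OC[C@H]1O`, carries on the core of compound 2 the same change, (acetyl in place of hydrogen on an oxygen on a saturated carbon), at an identically described place. Because a 1.4-fold lower number from compound 3 to compound 1 (0.13 log units; within the scatter) stayed within the scatter, the expected step is a 1.3-fold lower number from compound 2 to compound 4 (0.11 log units; within the scatter), a small one. Compound 4 is therefore estimated at 6.5 uM, likely between 2.5 uM and 17 uM.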

Compound 4, concentration for half-maximal effect: 1.71 uM
Compound 4: the middle estimate sits 3.8-fold (0.58 log units) above what was measured; measured number below the stated range.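

Replacing hydroxy with acetoxy does not carry over at a fixed size between these cores. In this assay, the change gives a 4.9-fold lower number from compound 2 to compound 4 (0.69 log units; beyond the scatter), and set beside the earlier step the difference is clear: the same change on two cores in this assay, a 1.4-fold lower number (0.13 log units; within the scatter) from compound 3 to compound 1 and a 4.9-fold lower number (0.69 log units; beyond the scatter) from compound 2 to compound 4, 3.6-fold (0.56 log units) apart, beyond the scatter of two such steps

This shows that a step read on the core of compound 3 was a poor guide to the step on the core of compound 2. Going by these compounds alone, with only two matched pairs, it does not show which part of the cores sets the steps apart, or how the change would behave on any other core.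

As far as these compounds go, it remains open whether a longer acyl chain in place of acetyl would give a similar step on each core. An amine in place of the hydroxy is likewise an open case.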